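A Trimethoxyphenyl Variant of Compound 1 Against HDAC6

A few compounds are considered here, and "the series" means these few. Any claim that something is new, unique, unknown or untested is made for them only; others in the source may bear on it.

Three compounds have been measured in an assay on isolated protein for inhibition of protein deacetylase HDAC6 (Homo sapiens); on this read-out lower numbers stand for stronger inhibition and higher numbers for weaker inhibition:

compound 1, `COc1ccc(C(=O)c2ccc3c(ccn3S(=O)(=O)c3cccc(/C=C/C(=O)NO)c3)c2)cc1`, 751 nM
compound 2, `Cc1ccc(C(=O)c2ccc3c(ccn3Cc3ccc(C(=O)NO)cc3)c2)cc1`, 11.9 nM
compound 3, `COc1ccc(C(=O)c2ccc3c(ccn3S(=O)(=O)c3ccc(/C=C/C(=O)NO)cc3)c2)cc1`, 848 nM

Compound 1 stands second highest of the three numbers. Its nearest neighbour is compound 3, whose value sits within the usual scatter of compound 1, so the two cannot be told apart on this read-out. Compound 2 lies far lower, well beyond the scatter, and is the only one of the three that shows strong inhibition in this assay.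

The next compound, compound 4, has the structure `COc1cc(C(=O)c2ccc3c(ccn3S(=O)(=O)c3cccc(/C=C/C(=O)NO)c3)c2)cc(OC)c1OC`. It differs from compound 1 in one place: 3,4,5-trimethoxyphenyl in place of 4-methoxyphenyl on a carbonyl carbon. The carbonyl carbon that carries this group is otherwise bound to an aromatic carbon, and the rest of the shared core is untouched.

Within the data shown here, no measured pair in this set shows what this particular change does, so the expectation rests on compound 1 alone. Since compound 1 and compound 3 differ elsewhere and still give values within the scatter of each other, a change of this kind is expected to move the number little, in no firm direction. The expected step from compound 1 to compound 4 is a 1.2-fold lower number from compound 1 to compound 4 (0.06 log units; within the scatter), within or close to the scatter. Compound 4 is therefore estimated at 650 nM, with a range from 250 nM to 1700 nM.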

Compound 4, half-maximal inhibitory concentration: 562 nM
Compound 4: the middle estimate sits 1.2-fold (0.06 log units) above what was measured; the measured number falls inside the stated range.
By their numbers in this assay, from the lowest: compound 2; then compounds 4, 1 and 3 (each within the scatter of the next).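

In this assay, the swap of 4-methoxyphenyl for 3,4,5-trimethoxyphenyl on the carbonyl carbon gives a 1.3-fold lower number from compound 1 to compound 4 (0.13 log units; within the scatter), so the two compounds cannot be told apart on this read-out. Among these compounds, this is the first pair in the set that differs in only one place, and it shows that this position can carry the two extra methoxy groups with no change that can be told from ordinary repeat-to-repeat variation. Nothing available explains this outcome.

Open, as far as these compounds go, is whether this position stays as undemanding with a group of another kind on the carbonyl carbon, such as a phenyl ring bearing an amine or a carboxylic acid, and whether the same swap would give a similar result with compound 3, which also carries 4-methoxyphenyl. Among the compounds shown here, also open is which feature sets compound 2 apart, since it differs from compound 1 and compound 4 in more than one place and no single-change pair connects it to them.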